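Cytotoxicity notes: acetylthiophene to methyl-oxadiazolylphenyl

This account rests on a few compounds, and the source may have more. Where it says the series, first, only, none or still open, it means among the compounds named here.

Compound 3 `CCOC(=O)CCCCCOc1cccc(CN(C(=O)c2ccc(-c3ccc(C(C)=O)s3)cc2)C(C)C)c1` is one of three biaryl amides on the shared core that have been run in an ADME assay on HEK293 cells (Homo sapiens) for cytotoxicity, read by CellTiter-Glo and resazurin assay, with a stated time of 72 h; on this read-out higher numbers stand for an effect only at larger amounts of compound and lower numbers for an effect already at smaller amounts. In this assay compound 3 gives only a limit, > 26000 nM. Compound 1 `CCOC(=O)CCCCCOc1cccc(CN(C(=O)c2ccc(-c3cccc(C(C)=O)c3)cc2)C(C)C)c1` likewise gives only a limit in this assay, > 26000 nM. Compound 2 `CCOC(=O)CCCCCOc1cccc(CN(C(=O)c2ccc(-c3cccc(OC(C)C)c3)cc2)C(C)C)c1` also sits at a limit in this assay, > 26000 nM. All three values rest at the limit of > 26000 nM in this assay, at which 3 of the 3 values shown sit, so the steps among them cannot be read: a step that the two limits leave unreadable from compound 1 to compound 2, a step that the two limits leave unreadable from compound 1 to compound 3 and a step that the two limits leave unreadable from compound 2 to compound 3. Compound 3 therefore stands where the other two stand, at the top of the measured range.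

Compound 4 `CCOC(=O)CCCCCOc1cccc(CN(C(=O)c2ccc(-c3cccc(-c4nnc(C)o4)c3)cc2)C(C)C)c1` has not yet been measured. It differs from compound 3 by 3-(5-methyl-1,3,4-oxadiazol-2-yl)phenyl in place of 5-acetylthiophen-2-yl on an aromatic carbon. The measured steps that bear on changes at this position are all unreadable between limits, so they give no size in either direction. The expectation for compound 4 is that it again reaches the limit, with a step that the limit leaves unreadable from compound 3 to compound 4 expected to be none beyond the scatter. Compound 4 is estimated at 30000 nM, in a range from 10000 nM to 100000 nM.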

Compound 4, half-maximal effective concentration: > 26000 nM
Compound 4: no number, only a limit (the forecaster's own chance of this, stated with the estimate: 85%); the middle value lies beyond the limit too.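

In this assay compound 4 also gives only a limit, > 26000 nM, so its steps to compound 1, compound 2 and compound 3 cannot be read: the limit of > 26000 nM in this assay, at which 4 of the 4 values shown sit. The compounds shown leave open at what concentration, if any, these four biaryl amides reach a half-maximal effect.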